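The source may hold more compounds than are shown below. What is called first, only, known or untested is meant among the compounds shown, and "the series" means these compounds.

Measured compounds:

Compound 1 `COc1ccc(Cl)cc1N1CCN(CCCCNc2c(C(C)=O)c(C)nn(C)c2=O)CC1` gives 5.96 nM in an assay on isolated protein for binding affinity to Alpha-1D adrenergic receptor (Homo sapiens), read by radioligand binding; on this read-out lower numbers stand for stronger inhibition and higher numbers for weaker inhibition.
Compound 2 `COc1ccc(Cl)cc1N1CCN(CCNc2c(C(C)=O)c(-c3ccccc3)nn(C)c2=O)CC1` gives 0.41 nM in this assay.
Compound 3 `COc1ccc(Cl)cc1N1CCN(CCCNc2cc(-c3ccccc3)nn(C)c2=O)CC1` gives 2.92 nM in this assay.

Among these three numbers compound 2 stands lowest, which here means the tightest binding. The nearest of the others is compound 3, and the gap between compound 2 and compound 3 lies beyond the usual scatter of repeated measurements; compound 1 stands further away still, also beyond the scatter. Compound 4 `CC(=O)c1c(-c2ccccc2)nn(C)c(=O)c1NCCN1CCN(c2ccccc2Cl)CC1` has not yet been measured. It differs from compound 2 in a single place: 2-chlorophenyl in place of 5-chloro-2-methoxyphenyl on an amine nitrogen in a ring. For the measured compounds named here, no pair of measured compounds shows this particular change, so its effect can only be expected, not read off. The group that leaves carries one hydrogen-bond acceptor, the group that enters carries none, and the substitution pattern on that ring is changed as well. The step from compound 2 to compound 4 is expected to be a modest move toward a higher number, possibly within the scatter but more likely just beyond it, as a 3.7-fold higher number from compound 2 to compound 4 (0.56 log units; beyond the scatter) expresses. For compound 4 the expected value in this assay is therefore 1.5 nM, within a range from 0.4 nM to 6 nM.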

Compound 4, inhibition constant: 0.25 nM
Beside the measured number, compound 4's estimate is 6.0-fold (0.78 log units) above it, outside the stated range (below it).
By their numbers in this assay, from the lowest: compounds 4 and 2 (each within the scatter of the next); then compound 3; then compound 1.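

In this assay, putting 2-chlorophenyl in place of 5-chloro-2-methoxyphenyl on the ring amine nitrogen gives a 1.6-fold lower number from compound 2 to compound 4 (0.21 log units; within the scatter), so the two compounds cannot be told apart. On this core, then, the tight binding seen with compound 2 does not depend on the methoxy group or its hydrogen-bond acceptor, and the simpler aryl group serves equally well. No measurement shown explains why the number holds when this group is exchanged.

The methoxy group and the chlorine changed together here, so their separate contributions cannot be read, and a plain phenyl or a 2-methoxyphenyl group on the same nitrogen would be needed to pull them apart. From the compounds shown here alone, it also remains open whether the same exchange would leave the number unchanged on the cores of compound 1 and compound 3, which carry longer chains.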